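The compounds below may be only part of what the source reports. "The series", "measured", "known", "first", "only" and "open" are said of these compounds alone.

In a functional assay on K562 cells (Homo sapiens) for inhibition, read by MTT assay, with a stated time of 5 days (a lower number here means a stronger inhibitor, a higher number a weaker inhibitor), compound 3 `COc1ccc(/C=C2\Oc3c(cc(OC)c(OC)c3OC)C2=O)cc1F` gives 110 nM, the lower of the two exact numbers and well beyond the scatter from compound 1 `COc1ccc(/C=C2\Oc3cc(OC)c(OC)c(OC)c3C2=O)cc1O`, which gives 18000 nM. Compound 2 `COc1cc2c(c(OC)c1OC)C(=O)/C(=C/c1cc(F)c(OC)c(F)c1)O2` reaches only a limit of the assay, > 50000 nM.

Compound 4 `COc1cc2c(c(OC)c1OC)O/C(=C\c1cc(F)c(OC)c(F)c1)C2=O` differs from compound 3 at one place, ortho to a methoxy group and meta to a fluoro group (fluoro in place of hydrogen on an aromatic carbon). Going by the values given here, no measured pair here shows a change of this kind, so the forecast is a judgement with a wide range. A modest weakening is expected, with the estimated step being a 2.7-fold higher number from compound 3 to compound 4 (0.44 log units; beyond the scatter). For compound 4 the estimated value is 300 nM, with an expected range of 50 nM to 3000 nM.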

Compound 4, half-maximal inhibitory concentration: 150 nM
For compound 4 the middle estimate is 2.0-fold (0.30 log units) above the measured one; low and high end bracket the measured number.
By their numbers in this assay, from the lowest: compounds 3 and 4 (each within the scatter of the next); then compound 1. At a limit, above all of these: compound 2.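

In this assay, fluoro in place of hydrogen on this aromatic carbon, ortho to a methoxy group and meta to a fluoro group, gives a 1.4-fold higher number from compound 3 to compound 4 (0.13 log units; within the scatter), so this position accepts the extra fluorine with no change that stands out from the scatter. Going by these compounds alone, this is the first single-place comparison in the set, and it shows that a number near the low end of the series survives the swap. Nothing measured here says why the number holds.

The compounds shown carry only hydrogen or fluoro at this position. On these data alone, how an amine or a longer chain would fare there stays open.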